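A methoxyphenyl swap in an antiproliferative series

This account rests on a few compounds, and the source may have more. Where it says the series, first, only, none or still open, it means among the compounds named here.

Measured in a functional assay on SW 1116 cells (Homo sapiens) for antiproliferative activity, read by MTT assay, with a stated time of 48 h; a higher number here means a weaker inhibitor, a lower number a stronger inhibitor:
- compound 1 `S=c1oc(-c2ccc3c(c2)OCCO3)nn1CN1CCN(c2cccc(Cl)c2Cl)CC1`: 37100 nM
- compound 2 `S=c1oc(-c2ccc3c(c2)OCCO3)nn1CN1CCN(c2ccc(Cl)cc2)CC1`: > 50000 nM, which is a limit
- compound 3 `COc1ccccc1N1CCN(Cn2nc(-c3ccc4c(c3)OCCO4)oc2=S)CC1`: 16900 nM

Of the two actual numbers, the lower belongs to compound 3, at 16900 nM, with compound 1 as its nearest neighbour. Compound 4 `COc1cccc(N2CCN(Cn3nc(-c4ccc5c(c4)OCCO5)oc3=S)CC2)c1` keeps the shared core but carries 3-methoxyphenyl in place of 2-methoxyphenyl on an amine nitrogen in a ring. Within the data shown here, no measured step makes this exact change, so the nearest guide is the other swaps at that nitrogen. These are a 2.2-fold lower number from compound 1 to compound 3 (0.34 log units; beyond the scatter) and an at least 2.9-fold lower number from compound 2 to compound 3 (0.47 log units; beyond the scatter), both beyond the scatter, and an at least 1.3-fold higher number from compound 1 to compound 2 (0.12 log units; that floor lies within the scatter), whose floor lies within it. Both other compounds stand on the higher side of compound 3, so a small move towards a higher number is expected in this assay. The expected step is a 1.8-fold higher number from compound 3 to compound 4 (0.25 log units; within the scatter). For compound 4 the estimate is 30000 nM, with an expected range of 13000 nM to 50000 nM.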

Compound 4, half-maximal inhibitory concentration: > 50000 nM
Compound 4: a limit, no number; the forecaster's own chance of this, stated with the estimate: 20%; middle value at least 1.6-fold (0.22 log units) from the limit.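

Swapping 2-methoxyphenyl for 3-methoxyphenyl changes only how the same atoms are joined, yet in this assay it gives an at least 2.9-fold higher number from compound 3 to compound 4 (0.47 log units; beyond the scatter), so the place of the methoxy group on this ring matters and compound 3 keeps the lowest number of the four, with its steps to all the others beyond the scatter. Compound 4 gives > 50000 nM, which is a limit, so this step has only a floor: the limit of > 50000 nM in this assay, at which 2 of the 4 values shown sit. The same group gives an at least 1.3-fold higher number from compound 1 to compound 4 (0.12 log units; that floor lies within the scatter), while the step between compound 2 and compound 4 cannot be read.

From the compounds shown here alone, how far compound 4 really lies from compound 3 stays open. So does whether a 4-methoxyphenyl or 2-ethoxyphenyl group on this nitrogen would match compound 3 in this assay.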